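The compounds below may be only part of what the source reports. "The series", "measured", "known", "first", "only" and "open" are said of these compounds alone.

Measured so far:
compound 1 `CC(=O)OCC(C)(C)NC(=O)N(CCC1CCN(Cc2ccc(C)cc2)CC1)Cc1ccc(-c2ccccc2)cc1` gives 366 nM in an in vitro functional assay on HEK293 cells for antagonist activity at melanin-concentrating hormone receptor 1 (Homo sapiens), read by GTPgammaS binding, with a stated time of 45 min; on this read-out lower numbers stand for stronger inhibition and higher numbers for weaker inhibition
compound 2 `Cc1ccc(CN2CCC(CCN(Cc3ccc(-c4ccccc4)cc3)C(=O)NC(C)(C)CO)CC2)cc1` gives 122 nM
compound 3 `CCC(CO)(CO)NC(=O)N(CCC1CCN(Cc2ccc(C)cc2)CC1)Cc1ccc(-c2ccc(F)cc2)cc1` gives 293 nM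

Compound 3 stands second highest of the three numbers; against compound 1 it lies within the scatter, against compound 2 beyond it. Compound 4 `CCC(CO)(CO)NC(=O)N(CCC1CCN(Cc2ccc(C)cc2)CC1)Cc1ccc(-c2ccccc2)cc1` differs from compound 3 by hydrogen in place of fluoro on an aromatic carbon; one bond further out this reads 4-fluorophenyl to phenyl. Within the data shown here, no measured step bears on this change: the only single-place step, a 3.0-fold lower number from compound 1 to compound 2 (0.48 log units; beyond the scatter), concerns the urea side chain, not the biaryl end. The expected step from compound 3 to compound 4, a 1.0-fold lower number from compound 3 to compound 4 (0.00 log units; within the scatter), is therefore set at none beyond the scatter. Compound 4 is estimated at 290 nM, range 120 nM to 700 nM.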

Compound 4, antagonist equilibrium constant: 147 nM
Beside the measured number, compound 4's estimate is 2.0-fold (0.30 log units) above it; measured number inside the range.
By their numbers in this assay, from the lowest: compounds 2, 4, 3 and 1 (each within the scatter of the next, the first and the last beyond it).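

In this assay, hydrogen in place of fluoro on the aromatic carbon stays within the scatter (a 2.0-fold lower number from compound 3 to compound 4 (0.30 log units; within the scatter)), so the 4-fluorophenyl to phenyl change leaves the number unresolved from compound 3. With phenyl fixed, 1,1-bis(hydroxymethyl)propyl on the amide-type nitrogen matches 1-(hydroxymethyl)-1-methylethyl within the scatter (a 1.2-fold higher number from compound 2 to compound 4 (0.08 log units; within the scatter)) but gives a modest step from the 1-(acetoxymethyl)-1-methylethyl group (a 2.5-fold lower number from compound 1 to compound 4 (0.40 log units; beyond the scatter)). No measurement shown accounts for these steps.

Open, going by these compounds, is how chloro or methoxy behaves on that aromatic carbon. Also open, on these data alone, is whether an amine or carboxylic acid in place of a hydroxymethyl group keeps the number.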